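The source may hold more compounds than are shown below. What is called first, only, known or untested is meant among the compounds shown, and "the series" means these compounds.

Measured compounds in an ADME assay on NCM460 cells (Homo sapiens) for cytotoxicity, read by MTT assay, with a stated time of 72 h; on this read-out lower numbers stand for stronger inhibition and higher numbers for weaker inhibition:
compound 1 `CCCCCN1C(=O)C/C(=C\c2cccc(C(=O)Nc3cccc(F)c3)c2)C1=O`: a limit only, > 100000 nM.
compound 2 `O=C(Nc1ccccc1)c1cccc(/C=C2\CC(=O)N(c3ccccc3)C2=O)c1`: a limit only, > 100000 nM.
compound 3 `Cc1ccc(NC(=O)c2cccc(/C=C3\CC(=O)N(c4ccccc4)C3=O)c2)cc1`: a limit only, > 100000 nM.

Among the compounds with values here, compound 3 stands at the limit of > 100000 nM in this assay, at which 3 of the 3 values shown sit, with no number in this assay; the single measured step, a step that the two limits leave unreadable from compound 2 to compound 3, is likewise unreadable. Compound 4 `O=C(Nc1cccc(F)c1)c1cccc(/C=C2\CC(=O)N(c3ccccc3)C2=O)c1` differs by 3-fluorophenyl in place of 4-methylphenyl on an amide-type nitrogen. Within the data shown here, no measured step bears on this change. The nearest point of comparison, compound 1, also carries 3-fluorophenyl on the amide-type nitrogen and sits at the same limit. In this assay, no step beyond the scatter is therefore expected, and compound 4 is expected to return a limit once more. The expected step that the limit leaves unreadable from compound 3 to compound 4 is none beyond the scatter. Compound 4 is estimated at 150000 nM, in the range 50000 nM to 500000 nM.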

Compound 4, half-maximal inhibitory concentration: > 100000 nM
Compound 4: a limit, no number; the forecaster's own chance of this, stated with the estimate: 90%; the middle value does not contradict the limit.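

No step from compound 1, compound 2 or compound 3 to compound 4 can be read in this assay: the limit of > 100000 nM in this assay, at which 4 of the 4 values shown sit.

The compounds shown leave open whether any of these changes shifts the read-out in this assay, as none of them has a number.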